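The compounds below may be only part of what the source reports. "The series", "measured", "known", "first", "only" and "open" are said of these compounds alone.

Measured so far:
compound 1 `c1cc(-c2nccs2)c2c(c1)C(c1ncc[nH]1)CC2`: 64%
compound 2 `Clc1ccc2c(c1-c1ccn[nH]1)CCC2c1ncc[nH]1`: 40%

In a functional assay on CHO cells for agonist activity at Alpha-1A adrenergic receptor (Homo sapiens), read by FLIPR and calcium flux (on this read-out higher numbers stand for larger maximal responses and lower numbers for smaller maximal responses), compound 1 gives 64%, the higher of the two numbers; compound 2 gives 40%, a gap beyond the scatter. Within the data shown here, no measured pair differs in one place only. Compound 3 `c1ccc2c(c1)CCC2c1ncc[nH]1` remains to be measured in this assay. From compound 1 it differs by hydrogen in place of 1,3-thiazol-2-yl on an aromatic carbon. Among the measured compounds shown here, no measured pair shows what such a change does in this assay, so the expected step from compound 1 to compound 3 is a moderate decrease, a number 14 percentage points lower from compound 1 to compound 3 (beyond the scatter), though a result within the scatter would not surprise. For compound 3 the expected maximal response is 50%, with a range from 25% to 75%.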

Compound 3, largest response reached (Emax), in percent of the reference or control that the assay uses: 54%
Beside the measured number, compound 3's estimate is 4 percentage points below it; the measured number falls inside the stated range.
By their numbers in this assay, from the lowest: compound 2; then compounds 3 and 1 (each within the scatter of the next).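

A step of a number 10 percentage points lower from compound 1 to compound 3 (within the scatter) in this assay comes with hydrogen in place of 1,3-thiazol-2-yl on this aromatic carbon. The maximal response thus shows no dependence on the 1,3-thiazol-2-yl beyond the scatter, and the core of compound 3, with only hydrogen at this place, gives a response that cannot be told from that of compound 1. No measurement at hand offers an explanation for this result.

Going by these compounds, it remains open whether a different group on this aromatic carbon, such as an amine, a carboxylic acid or a longer alkyl chain, would move the response beyond the scatter. On these data alone, whether other five-membered aromatic rings here behave like 1,3-thiazol-2-yl also remains open.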